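Adding a Carbamoylmethyl Arm to a Glycine Ester

This account rests on a few compounds, and the source may have more. Where it says the series, first, only, none or still open, it means among the compounds named here.

Of the compounds shown here, three have been measured in a functional assay on the whole organism (Tail, strain ICR) with Mus musculus as the target, in the tail flick test, with a stated time of 90 min, at a dose of 25 umol/kg by the oral route; on this read-out lower numbers stand for a weaker effect and higher numbers for a stronger effect at the one dose given. Compound 1 `O=C(CN(c1ncnc2c1ncn2C1CCCCO1)C1CC1)NCC(=O)OCc1ccccc1` gives 25.9%. Compound 3 `O=C(O)CNC(=O)CN(c1nc(Cl)nc2[nH]cnc12)C1CC1` gives 32.3%, and compound 2 `NCCCC[C@H](NC(=O)CN(c1nc(Cl)nc2[nH]cnc12)C1CC1)C(=O)OCc1ccccc1` gives 35.3%; both of these numbers sit within the usual scatter of the number of compound 1, so the three cannot be set apart from each other on this read-out.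

Compound 4 `NC(=O)C[C@H](NC(=O)CN(c1ncnc2c1ncn2C1CCCCO1)C1CC1)C(=O)OCc1ccccc1` has not yet been measured in this assay. It differs from compound 1 by carbamoylmethyl in place of hydrogen on a saturated chain carbon bound to an amide-type nitrogen and a carbonyl carbon. Going by the values given here, no measured pair in the set shows this change, so there is no step to lean on. Compound 4 is expected to score near compound 1, with an estimated step of a number 4.1 percentage points higher from compound 1 to compound 4 (within the scatter) that stays within the scatter. The expected value for compound 4 is 30%, between 15% and 45%.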

Compound 4, a percentage reported as activity, at one dose (the size of the read-out at that dose, not a potency): 35%
Beside the measured number, compound 4's estimate is 5 percentage points below it; low and high end bracket the measured number.
By their numbers in this assay, from the lowest: compounds 1, 3, 4 and 2 (each within the scatter of the next).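

In this assay, carbamoylmethyl in place of hydrogen on a saturated chain carbon bound to an amide-type nitrogen and a carbonyl carbon gives a number 9.1 percentage points higher from compound 1 to compound 4 (within the scatter). Going by these compounds alone, this is the first step read at this position, and it shows that the core of compound 1 tolerates this arm here without the read-out moving beyond the usual scatter. No measurement available here bears on the reason for this result.

As far as these compounds go, whether a methyl or a hydroxymethyl group at the same carbon would also stay within the scatter remains open. A single dose also leaves the potency of compound 4 unresolved.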